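Swapping isopropyl for trifluoromethoxy on the benzyl ring

The source may hold more compounds than are shown below. What is called first, only, known or untested is meant among the compounds shown, and "the series" means these compounds.

Of the compounds shown here, two sharing one core have been measured in a physicochemical assay for lipophilicity, read by HPLC, measured as chromatographic lipophilicity, at pH 7.4; on this read-out lower numbers stand for lower lipophilicity and higher numbers for higher lipophilicity. Compound 1, `COc1cccc(NC(=O)c2nnn(Cc3ccc(C#N)cc3)c2N)c1`, gives 2.3 in this assay. Compound 2, `COc1cccc(NC(=O)c2nnn(Cc3ccc(C(C)C)cc3)c2N)c1`, gives 3.4 in this assay. Among the measured compounds shown here, the only step between them, a number 1.10 log units higher from compound 1 to compound 2 (beyond the scatter), shows that the group on that aromatic carbon moves the number a good deal. Compound 2 therefore stands highest of the two measured numbers, with compound 1 the nearest.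

Compound 3, `COc1cccc(NC(=O)c2nnn(Cc3ccc(OC(F)(F)F)cc3)c2N)c1`, differs from compound 2 in one place: trifluoromethoxy in place of isopropyl on an aromatic carbon. The step from compound 1 to compound 2 is the only one that bears on this position, and it was large, so the group at this spot matters. Trifluoromethoxy is neither the cyano of compound 1 nor the isopropyl of compound 2, so a modest shift is expected, a number 0.20 log units lower from compound 2 to compound 3 (within the scatter), rather than a large one. Compound 3 is estimated at 3.2, within 2.8 to 3.6.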

Compound 3, distribution coefficient: 3.6
The estimate for compound 3 lay 0.40 log units below the measured number, within the range that was stated.
By their numbers in this assay, from the lowest: compound 1; then compounds 2 and 3 (each within the scatter of the next).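

In this assay, trifluoromethoxy and isopropyl cannot be told apart on this aromatic carbon (the step is a number 0.20 log units higher from compound 2 to compound 3 (within the scatter)), even though the two groups are built differently: trifluoromethoxy brings oxygen, fluorine and a hydrogen-bond acceptor, while isopropyl has carbon only and no acceptor. The large shift seen earlier now has a second example (a number 1.30 log units higher from compound 1 to compound 3 (beyond the scatter)), so compound 1 with its cyano group stands apart from both other compounds. Nothing available explains why these two different groups land so close together or why cyano stands apart.

The compounds shown leave open where an amine, a carboxylic acid or a longer alkyl chain would fall on this carbon. They also leave open whether these swaps would behave the same way on a different core, since all three compounds share one.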